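Methoxy removed on an aromatic carbon: cytotoxicity notes

The source may hold more compounds than are shown below. What is called first, only, known or untested is meant among the compounds shown, and "the series" means these compounds.

Compound 1 `C=CC1=C(C(=O)Nc2ccccc2OC)C(c2ccc(F)cc2)OC1` and compound 2 `C=CC1=C(C(=O)Nc2ccccc2)C(c2ccc(F)cc2)OC1` share one core; the difference between that core and the core of compound 3 `C=CC1=C(C(=O)NCCC)C(c2ccc(OC)c(OC)c2)OC1` is not broken down here. In a functional assay on SW480 cells (Homo sapiens) for cytotoxicity, read by MTT assay, with a stated time of 24 h (a higher number here means a weaker inhibitor, a lower number a stronger inhibitor), compound 1 gives only a limit, > 100000 nM. In this assay compound 2 likewise gives only a limit, > 100000 nM. Compound 3 also reaches only a limit in this assay, > 100000 nM. The change from compound 1 to compound 2, (hydrogen in place of methoxy on an aromatic carbon), therefore shows a step that the two limits leave unreadable from compound 1 to compound 2. Compound 4 `C=CC1=C(C(=O)NCCC)C(c2ccc(OC)cc2)OC1` arises from compound 3 by the same kind of change, (hydrogen in place of methoxy on an aromatic carbon), though here the place is ortho to a methoxy group and meta to a large group rather than ortho to a large group. Among the compounds with values here, since every value so far sits at the limit of > 100000 nM in this assay, at which 3 of the 3 values shown sit, compound 4 is expected to remain at that limit as well. The expected step is a step that the limit leaves unreadable from compound 3 to compound 4. The estimate for compound 4 is 150000 nM, within 60000 nM to 400000 nM.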

Compound 4, half-maximal inhibitory concentration: > 100000 nM
Compound 4: no number, only a limit; the forecaster's own chance of this, stated with the estimate: 85%; the middle value does not contradict the limit.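

Compound 3 and compound 4 both give only limits in this assay, so the step between them cannot be read: the limit of > 100000 nM in this assay, at which 4 of the 4 values shown sit. The compounds shown leave open whether removing a methoxy group changes cytotoxicity at all.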